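From a chlorophenyl amide to a pyridinyl amide

This account rests on a few compounds, and the source may have more. Where it says the series, first, only, none or still open, it means among the compounds named here.

The three measured compounds share one core. Compound 1 `COc1cc2c(cc1OC)C(CC(=O)O)CC2` carries a free carboxylic acid, and in a functional assay on the whole organism (strain Swiss Albino) for inhibition, with Mus musculus as the target, in the writhing test, with a stated time of 1 h, at a dose of 100 mg/kg by the oral route (a higher number here means more inhibition at the dose given (going by the name of the read-out), a lower number less inhibition), compound 1 gives 44%. Compound 2 `COc1cc2c(cc1OC)C(CC(=O)Nc1cccc(Cl)c1)CC2` is the (3-chlorophenyl)amino amide of that acid; in this assay compound 2 gives 51.5%, the highest of the three numbers, though the step of a number 7.5 percentage points higher from compound 1 to compound 2 (within the scatter) stays within the scatter. Compound 3 `COc1cc2c(cc1OC)C(CC(=O)Nc1ccccc1C)CC2`, the (2-methylphenyl)amino amide, gives 30% in this assay, and the step of a number 14 percentage points lower from compound 1 to compound 3 (beyond the scatter) lies beyond the scatter. Compound 2 therefore stands nearest to compound 1 and furthest from compound 3.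

Compound 4 `COc1cc2c(cc1OC)C(CC(=O)Nc1ccccn1)CC2` is a further amide of the same acid: pyridin-2-yl in place of 3-chlorophenyl on an amide-type nitrogen. For the measured compounds named here, the only measured step that also swaps the ring on the amide-type nitrogen is a number 21.5 percentage points lower from compound 2 to compound 3 (beyond the scatter), a modest fall. Going by the values given here, no measured compound carries pyridin-2-yl, so nothing directly shows how a ring with a hetero atom behaves here. The step of a number 21.5 percentage points lower from compound 2 to compound 3 (beyond the scatter) does show that the number can drop when that ring changes. A small fall, possibly within the scatter, is therefore expected for compound 4: a number 11.5 percentage points lower from compound 2 to compound 4 (beyond the scatter). In this assay compound 4 is estimated at 40%, with a range from 25% to 55%.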

Compound 4, a percentage reported as inhibition, in the whole organism at one dose (the size of the read-out at that dose, not a potency): 48.1%
The estimate for compound 4 lay 8.1 percentage points below the measured number; measured number inside the range.
By their numbers in this assay, from the lowest: compound 3; then compounds 1, 4 and 2 (each within the scatter of the next).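

Placing pyridin-2-yl in place of 3-chlorophenyl on the amide-type nitrogen gives a number 3.4 percentage points lower from compound 2 to compound 4 (within the scatter) in this assay, so a ring with one hetero atom and no chlorine can stand at this position without a separable change in the number. Compared with the free acid, the new amide gives a number 4.1 percentage points higher from compound 1 to compound 4 (within the scatter), which means that compound 4, like compound 2, cannot be told apart from compound 1 in this test. Changing the ring on this nitrogen therefore does not always lower the number: the swap of 2-methylphenyl for pyridin-2-yl gives a number 18.1 percentage points higher from compound 3 to compound 4 (beyond the scatter), and among the compounds shown, only compound 3 stands apart from the others.

Nothing in the data bears on why the rings give these numbers. Going by these compounds, the amide with a plain phenyl ring and the one with a pyridin-3-yl ring stay open, and these two would help to show whether the chlorine, the ring nitrogen or the place of that nitrogen in the ring matters here.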